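Removing a Methyl from a Weak Binder

The compounds below may be only part of what the source reports. "The series", "measured", "known", "first", "only" and "open" are said of these compounds alone.

Compound 3 `Cc1ccc(C(Nc2ccc(C)cc2Cl)C(=O)CCc2ccncc2)cc1` carries a methyl on an aromatic ring of carbon only. In an assay on isolated protein for binding affinity to corticotropin-releasing factor receptor 1 (Homo sapiens) (on this read-out higher numbers stand for weaker inhibition and lower numbers for stronger inhibition), compound 3 gives only a limit, > 10000 nM. Compound 2 `Cc1ccc(NC(C(=O)CCc2ccncc2)c2ccc(Cl)cc2)c(Cl)c1` likewise reaches only a limit in this assay, > 10000 nM. The step that the two limits leave unreadable from compound 2 to compound 3 therefore cannot be sized. Compound 1 `C=Cc1ccccc1C(Nc1ccc(C)cc1Cl)C(=O)CCc1ccncc1`, whose corresponding ring is substituted differently, gives 752 nM; 752 nM (2 entries) in this assay. The measured record is thin: the limit of > 10000 nM in this assay, at which 2 of the 3 values shown sit. Compound 4 `Cc1ccc(NC(C(=O)CCc2ccncc2)c2ccccc2)c(Cl)c1` drops the methyl: hydrogen in place of methyl on an aromatic carbon, so 4-methylphenyl becomes plain phenyl. Going by the values given here, no measured step reads out what this change does, and the only firm number comes from compound 1, whose ring is altered in another way. Compound 4 is therefore expected to remain weak, with an estimated 9000 nM, lying between 2000 nM and 30000 nM. The expected step of an at least 1.1-fold lower number from compound 3 to compound 4 (0.04 log units; that floor lies within the scatter) is thus modest, and it is expected that compound 4 may again return only a limit rather than a number.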

Compound 4, inhibition constant: > 10000 nM
Compound 4: a limit, no number (the forecaster's own chance of this, stated with the estimate: 55%); at least 1.1-fold (0.04 log units) between middle value and limit.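

In this assay, going by these compounds alone, compound 4 gives only a limit, > 10000 nM, so no step among compound 2, compound 3 and compound 4 can be read. The compounds shown leave open whether replacing the methyl with hydrogen changes binding at all, with the record resting largely on: the limit of > 10000 nM in this assay, at which 3 of the 4 values shown sit.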